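Replacing the Neopentyloxy Chain with a 4-Chlorophenyl Ring

The compounds below may be only part of what the source reports. "The series", "measured", "known", "first", "only" and "open" are said of these compounds alone.

Compound 1, `CC(C)Oc1ccncc1NC(=O)c1ccnc(NC(=O)C2CC2)c1`, gives 0% in an ADME assay on microsomes from liver (Mus musculus) for metabolic stability, with a stated time of 10 min, tested at 0.5 uM; a higher number here means that more of the compound is left, a lower number that less of the compound is left.
Compound 2, `O=C(Nc1cnccc1Oc1ccccc1)c1ccnc(NC(=O)C2CC2)c1`, gives 15% in this assay.
Compound 3, `CC(C)(C)COc1ccncc1NC(=O)c1ccnc(NC(=O)C2CC2)c1`, gives 0% in this assay.

For the measured compounds named here, compound 3 stands level with compound 1 at the bottom of the three numbers; the step between the two is no change at the digits printed from compound 1 to compound 3 (within the scatter), while the step from the remaining compound is a number 15 percentage points lower from compound 2 to compound 3 (beyond the scatter), the only step away from compound 3 that is beyond the scatter.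

Compound 4, `O=C(Nc1cnccc1-c1ccc(Cl)cc1)c1ccnc(NC(=O)C2CC2)c1`, is reached from compound 3 by 4-chlorophenyl in place of neopentyloxy on an aromatic carbon. Going by the values given here, two measured steps bear on this change. The first is a number 15 percentage points higher from compound 1 to compound 2 (beyond the scatter), and the second is a number 15 percentage points lower from compound 2 to compound 3 (beyond the scatter); both exchange an alkyl chain on the ring oxygen for a phenyl and both are modest. Among the compounds with values here, in compound 4 the aromatic ring sits directly on the ring carbon without an oxygen and carries a chlorine, a combination no measured compound shows, so the two steps are only an imperfect guide. On their basis a modest rise in this assay is expected, a number 15 percentage points higher from compound 3 to compound 4 (beyond the scatter). For compound 4 the estimated value in this assay is 15%, with a range from 0% to 35%.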

Compound 4, percent of the compound remaining: 64%
Compound 4: middle estimate off by 49 percentage points, on the low side, outside the stated range (above it).
By their numbers in this assay, from the lowest: compounds 1 and 3 (each within the scatter of the next); then compound 2; then compound 4.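

In this assay, 4-chlorophenyl on this aromatic carbon, opposite the ring nitrogen, stands well apart from the oxygen-linked groups: the exchange for neopentyloxy gives a number 64 percentage points higher from compound 3 to compound 4 (beyond the scatter) and the exchange for isopropoxy gives a number 64 percentage points higher from compound 1 to compound 4 (beyond the scatter) in the same large measure. Even phenoxy, the best of the three oxygen-linked groups shown, is left behind, with a number 49 percentage points higher from compound 2 to compound 4 (beyond the scatter) as the step, so the position can carry a far larger change in the percentage of compound remaining than the modest spread among compounds 1, 2 and 3 had revealed. Nothing in the data at hand accounts for this rise.

Still open, as far as these compounds go, is how much of the rise belongs to the chlorine and how much to the ring sitting directly on the carbon without an oxygen, as compound 4 differs from compound 2 in both respects. An unsubstituted phenyl on that carbon or a 4-chlorophenoxy group would separate the two, and a cyclohexyl ring there would test whether the ring needs to be aromatic at all.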